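The source may hold more compounds than are shown below. What is called first, only, known or untested is meant among the compounds shown, and "the series" means these compounds.

In a functional assay on HeLa cells (Homo sapiens) for antiproliferative activity, read by MTT assay, with a stated time of 48 h (a lower number here means a stronger inhibitor, a higher number a weaker inhibitor), compound 3 `CCn1cc(-c2ccc(OC)cc2)c(=O)c2cc(F)c(N3CCNCC3)cc21` gives 69000 nM, within the scatter of compound 2 `CCn1cc(-c2ccc(F)cc2)c(=O)c2cc(F)c(N3CCNCC3)cc21` at 60900 nM. Compound 1 `CCn1cc(-c2nc3ccc([N+](=O)[O-])cc3o2)c(=O)c2cc(F)c(N3CCNC(C)C3)c(F)c21`, which differs in several places, gives 2980 nM, a number clearly lower than both. Compound 4 `CCn1cc(-c2cccc(OC)c2)c(=O)c2cc(F)c(N3CCNCC3)cc21` holds the same atoms as compound 3, joined differently: 3-methoxyphenyl in place of 4-methoxyphenyl on an aromatic carbon. Within the data shown here, the one measured single-place step is a 1.1-fold higher number from compound 2 to compound 3 (0.05 log units; within the scatter), methoxy in place of fluoro on an aromatic carbon. Among the measured compounds shown here, no measured pair tests a shift of the methoxy group, so that small step is only indirect guidance, and no change beyond the scatter is expected in this assay. The estimated step is a 1.2-fold lower number from compound 3 to compound 4 (0.06 log units; within the scatter). Compound 4 is expected at 60000 nM, with an estimated range of 28000 nM to 110000 nM.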

Compound 4, half-maximal inhibitory concentration: 12200 nM
Compound 4: middle estimate off by 4.9-fold (0.69 log units), on the high side; measured number below the stated range.
By their numbers in this assay, from the lowest: compound 1; then compound 4; then compounds 2 and 3 (each within the scatter of the next).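

In this assay, this aromatic carbon responds to where the methoxy group sits on the phenyl ring, not only to which group the ring carries: 3-methoxyphenyl in place of 4-methoxyphenyl gives a 5.7-fold lower number from compound 3 to compound 4 (0.75 log units; beyond the scatter). The same holds against the fluoro compound, with a 5.0-fold lower number from compound 2 to compound 4 (0.70 log units; beyond the scatter), although compound 2 and compound 3 lie within the scatter of each other. No evidence on the origin of this shift is available. Open, on these data alone, is whether an ethoxy group or an amine, carried on the phenyl ring where compound 4 has its methoxy group, would keep the lower number.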